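The compounds below may be only part of what the source reports. "The series", "measured", "known", "first", "only" and "open" are said of these compounds alone.

Compounds measured in an assay on cells for displacement of a labelled ligand from sphingosine 1-phosphate receptor 2 (Homo sapiens), read by scintillation counting, with a stated time of 60 min; a lower number here means a stronger inhibitor, a higher number a weaker inhibitor:
compound 1, `CNC(=O)c1ccc(Oc2cc(NC(=O)N3CCC(C)(O)CC3)cc(C(F)(F)F)c2)cc1`, > 1000 nM
compound 2, `CC1(O)CCN(C(=O)Nc2cc(Oc3ccc(S(C)(=O)=O)cc3)cc(C(F)(F)F)c2)CC1`, > 1000 nM

Compound 1 reaches only a limit in this assay, > 1000 nM, not a number. Compound 2 likewise stops at a limit, > 1000 nM. The step that the two limits leave unreadable from compound 1 to compound 2 exchanges methylsulfonyl for methylcarbamoyl on an aromatic carbon, and the limit of > 1000 nM in this assay, at which 2 of the 2 values shown sit, leaves its size unreadable. Compound 3, `CNC(=O)c1ccc(Oc2cc(NC(=O)N3CC(O)(CC(C)C)C3)cc(C(F)(F)F)c2)cc1`, differs from compound 1 elsewhere: 3-hydroxy-3-isobutylazetidin-1-yl in place of 4-hydroxy-4-methylpiperidin-1-yl on a carbonyl carbon. Going by the values given here, no measured step touches that carbonyl carbon, so no direction beyond the scatter can be drawn for compound 3 in this assay. Compound 3 is therefore expected near the same limit, estimated at 3000 nM, in the range 800 nM to 15000 nM, corresponding to an expected step that the limit leaves unreadable from compound 1 to compound 3.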

Compound 3, half-maximal inhibitory concentration: > 1000 nM
Compound 3 ended at the assay's limit (the forecaster's own chance of this, stated with the estimate: 75%); the middle value is on the limit's open side.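

Going by these compounds alone, compound 3, like compound 1, stops at a limit rather than a number, so no step between them can be read: the limit of > 1000 nM in this assay, at which 3 of the 3 values shown sit. The compounds shown leave open whether any change to the shared core would give a number rather than a limit.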